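The source may hold more compounds than are shown below. What is called first, only, known or untested is meant among the compounds shown, and "the series" means these compounds.

Measured compounds in a functional assay on HCT-116 cells (Homo sapiens) for inhibition, read by sulforhodamine B assay, with a stated time of 72 h; on this read-out higher numbers stand for weaker inhibition and lower numbers for stronger inhibition:
Compound 1 `COc1ccc2cc(C(C)c3nnc4n3N=C(c3ccc(OC(F)(F)F)cc3)CS4)ccc2c1` gives 11700 nM.
Compound 2 `COc1ccc2cc(C(C)c3nnc4n3N=C(c3ccc(Br)cc3)CS4)ccc2c1` gives 11700 nM.
Compound 3 `COc1ccc2cc(C(C)c3nnc4n3N=C(c3ccc(Cl)cc3)CS4)ccc2c1` gives 8800 nM.

Compound 3 carries the lowest of the three numbers, but its separation from the other two is small: a 1.3-fold lower number from compound 1 to compound 3 (0.12 log units; within the scatter) and a 1.3-fold lower number from compound 2 to compound 3 (0.12 log units; within the scatter), and likewise no change at the digits printed from compound 1 to compound 2 (within the scatter). None of the three compounds therefore stands apart from the others beyond the scatter, and compound 3 cannot be called the most potent of the set.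

Compound 4 `COc1ccc2cc(C(C)c3nnc4n3N=C(c3ccc(C)cc3)CS4)ccc2c1` differs from compound 3 in one place: methyl in place of chloro on an aromatic carbon. The measured steps that bear on this change are the three exchanges at the same aromatic carbon among compounds 1, 2 and 3, each of which stayed within the scatter. A further exchange at that carbon is expected to behave in the same way, so the estimated step of a 1.1-fold higher number from compound 3 to compound 4 (0.03 log units; within the scatter) is expected to remain within the scatter, with no direction assigned. Compound 4 is accordingly expected to give about 9500 nM in this assay, with an estimated range from 4500 nM to 20000 nM that allows for the usual scatter around a number close to that of compound 3.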

Compound 4, half-maximal inhibitory concentration: 10200 nM
For compound 4 the middle estimate is 1.1-fold (0.03 log units) below the measured one; the range from low to high includes it.
By their numbers in this assay, from the lowest: compounds 3, 4, 1 and 2 (each within the scatter of the next).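

In this assay, methyl on this aromatic carbon, para to a large group, reads as a 1.2-fold higher number from compound 3 to compound 4 (0.06 log units; within the scatter), as a 1.1-fold lower number from compound 2 to compound 4 (0.06 log units; within the scatter) and as a 1.1-fold lower number from compound 1 to compound 4 (0.06 log units; within the scatter), all three within the scatter. The earlier exchanges covered only chloro, bromo and trifluoromethoxy, whereas this result extends the same flat picture to a carbon group, so the 4-chlorophenyl to 4-methylphenyl change leaves the read-out indistinguishable and gives no order among the four compounds. Nothing available here accounts for this flatness.

Still open, on these data alone, is whether an amine, a carboxylic acid or a longer alkyl chain on this carbon would move the number beyond the scatter. Also open, as far as these compounds go, is whether a change elsewhere on the shared core, such as at its methoxy group, would do so.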